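Para bromo on the benzyl of compound 3

This account rests on a few compounds, and the source may have more. Where it says the series, first, only, none or still open, it means among the compounds named here.

The measured compounds and their values in a functional assay on PANC-1 cells (Homo sapiens) for inhibition, read by MTT assay, with a stated time of 72 h; a higher number here means a weaker inhibitor of growth, a lower number a stronger inhibitor of growth:
compound 1, `O=S(=O)(NCCCNCc1ccccc1Cl)c1cc(C(F)(F)F)cc(C(F)(F)F)c1`, 15000 nM
compound 2, `CC(C)(C)c1ccc(CNCCCNS(=O)(=O)c2cc(C(F)(F)F)cc(C(F)(F)F)c2)cc1`, 2500 nM
compound 3, `O=S(=O)(NCCCNCc1ccccc1)c1cc(C(F)(F)F)cc(C(F)(F)F)c1`, 16000 nM

Compound 3 carries the plain benzyl group on the shared core and gives the highest of the three numbers in this assay; its nearest neighbour is compound 1, a 1.1-fold higher number from compound 1 to compound 3 (0.03 log units; within the scatter), and the furthest is compound 2, a 6.4-fold higher number from compound 2 to compound 3 (0.81 log units; beyond the scatter).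

Compound 4 is `O=S(=O)(NCCCNCc1ccc(Br)cc1)c1cc(C(F)(F)F)cc(C(F)(F)F)c1`. It differs from compound 3 in one place: bromo in place of hydrogen on an aromatic carbon, on an aromatic carbon of a six-membered aromatic ring of carbon only, para to a large group; read one bond further out, benzyl becomes 4-bromobenzyl.

Among the measured compounds shown here, two measured steps bear on this change. Substitution at the same para position is covered by a 6.4-fold higher number from compound 2 to compound 3 (0.81 log units; beyond the scatter), a modest step beyond the scatter. A halogen on the same ring, though at another position, is covered by a 1.1-fold higher number from compound 1 to compound 3 (0.03 log units; within the scatter), which stayed within the scatter. Bromo is a single heavy atom and smaller than tert-butyl, so a step in this assay smaller than that of compound 2 but in the same direction is expected, a 2.0-fold lower number from compound 3 to compound 4 (0.30 log units; within the scatter).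

Compound 4 is therefore estimated at 8000 nM in this assay, within 3000 nM to 20000 nM.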

Compound 4, concentration for 50% growth inhibition: 2200 nM
Compound 4: the middle estimate sits 3.6-fold (0.56 log units) above what was measured; measured number outside the range, below it.
By their numbers in this assay, from the lowest: compounds 4 and 2 (each within the scatter of the next); then compounds 1 and 3 (each within the scatter of the next).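

In this assay, the single bromine para to a large group is enough to give a 7.3-fold lower number from compound 3 to compound 4 (0.86 log units; beyond the scatter), so this place on the ring responds to one heavy atom and does not need a group as large as tert-butyl. The exchange of tert-butyl for bromo gives a 1.1-fold lower number from compound 2 to compound 4 (0.06 log units; within the scatter), which stays within the scatter, so these two very differently sized groups cannot be told apart here, and among the compounds shown the size of the group para to a large group does not set the number. The change from the 2-chlorophenyl of compound 1 to 4-bromophenyl gives a 6.8-fold lower number from compound 1 to compound 4 (0.83 log units; beyond the scatter), which sets this result apart from the chloro of compound 1, whose number stayed within the scatter of the unsubstituted compound 3, so a halogen on this ring does not by itself lower the number among these compounds.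

Nothing available here accounts for the effect of this substitution on growth inhibition.

Open, going by these compounds, is whether fluoro, chloro, methoxy, an amine or a carboxylic acid at this same place would behave like bromo and tert-butyl, and whether the 4-bromobenzyl gain would hold with a longer chain.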